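Swapping Cyclopropyl for Bromo: Expected Cytotoxicity

This account rests on a few compounds, and the source may have more. Where it says the series, first, only, none or still open, it means among the compounds named here.

Two compounds have been measured:
- compound 1 `C[C@H]1[C@H](NCc2sccc2C2CC2)C[C@H]2C[C@@H]1C2(C)C` gives 25000 nM
- compound 2 `C=Cc1csc(CN[C@@H]2C[C@H]3C[C@@H]([C@H]2C)C3(C)C)c1` gives 6250 nM

Both were tested in an ADME assay on MDCK cells (Canis lupus familiaris) for cytotoxicity, read by microscopy, with a stated time of 48 h; on this read-out lower numbers stand for higher toxicity in this test and higher numbers for lower toxicity in this test. Of the two numbers, compound 1 stands at the higher one, and the number of compound 2 lies lower by a gap that is beyond the usual scatter, so compound 2 is the more toxic of the pair in this assay.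

The step followed here goes from compound 1 to compound 3 `C[C@H]1[C@H](NCc2sccc2Br)C[C@H]2C[C@@H]1C2(C)C`, which has not yet been measured. The change is bromo in place of cyclopropyl on an aromatic carbon. Nothing in the two measured compounds shows a step of exactly this kind, so the direction is open. The spread between compound 1 and compound 2 shows how much a small change on this ring can move the read-out. The expectation is that the change from compound 1 to compound 3 lowers the number somewhat, by about a 2.0-fold lower number from compound 1 to compound 3 (0.30 log units; within the scatter), with a wide margin of doubt. Compound 3 is therefore estimated at 12500 nM, in a range from 3000 nM to 50000 nM.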

Compound 3, minimum cytotoxic concentration: 50000 nM
The estimate for compound 3 lay 4.0-fold (0.60 log units) below the measured number; low and high end bracket the measured number.
By their numbers in this assay, from the lowest: compound 2; then compounds 1 and 3 (each within the scatter of the next).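

In this assay the swap of cyclopropyl for bromo on an aromatic carbon of the five-membered aromatic ring with 1 sulfur gives a 2.0-fold higher number from compound 1 to compound 3 (0.30 log units; within the scatter) and so cannot be told apart from repeat-to-repeat variation. Among the compounds shown here, this is the first direct comparison at this place, next to the ring atom that bears a large group, and for this pair the three-membered ring of the cyclopropyl group is not needed to keep the read-out within the scatter. No measurement shown here explains why the two groups read alike, so this remains an observation about one pair of compounds and not a rule about the position.

What the compounds shown leave open is whether a chloro or methyl group at this same place would also stay within the scatter, or whether an amine or a carboxylic acid there would move the number clearly in either direction. A single pair also cannot say whether the same swap would read alike on a core other than that of compound 1.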